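The compounds below may be only part of what the source reports. "The series", "measured", "known", "first", "only" and "open" are said of these compounds alone.

Measured so far:
compound 1 `CC1=CC[C@H](C(C)(C)NC(=S)NN)CC1` — 41900 nM
compound 2 `CC1=CC[C@H](C(C)(C)NC(=S)N/N=C/c2ccccc2O)CC1` — 5500 nM
compound 3 `CC1=CC[C@H](C(C)(C)NC(=S)N/N=C/c2ccccc2Cl)CC1` — 15100 nM

In a functional assay on OVCAR-3 cells (Homo sapiens) for inhibition, read by sulforhodamine B assay, with a stated time of 48 h (on this read-out lower numbers stand for stronger inhibition of growth and higher numbers for weaker inhibition of growth), compound 1 gives the highest of the three numbers. Compound 2 gives 5500 nM and compound 3 gives 15100 nM, so each hydrazone sits well under compound 1, and the step of a 2.7-fold higher number from compound 2 to compound 3 (0.44 log units; beyond the scatter) shows that the hydroxy-bearing ring and the chloro-bearing ring do not land at the same place.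

Compound 4 `CC1=CC[C@H](C(C)(C)NC(=S)N/N=C/c2ccco2)CC1` carries the change (a group of 7 heavy atoms (5 carbon, 1 nitrogen, 1 oxygen; one five-membered aromatic ring with 1 hetero atom) in place of one nitrogen atom, on an amide-type nitrogen). Within the data shown here, no measured step covers a five-membered aromatic ring with one hetero atom at this nitrogen; what bears on it is the pattern that both compounds 2 and 3 fall clearly below compound 1, together with the size of the spread between them given by a 2.7-fold higher number from compound 2 to compound 3 (0.44 log units; beyond the scatter). The expectation is therefore a clearly lower number for compound 4 in this assay than for compound 1, most likely landing within the span set by compound 2 and compound 3 rather than below it. The expected step is a 3.5-fold lower number from compound 1 to compound 4 (0.54 log units; beyond the scatter). The estimate for compound 4 is 12000 nM, with a range from 5000 nM to 30000 nM.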

Compound 4, concentration for 50% growth inhibition: 10800 nM
Estimate against measurement, compound 4: 1.1-fold (0.05 log units) above; the measured number falls inside the stated range.
By their numbers in this assay, from the lowest: compounds 2, 4 and 3 (each within the scatter of the next, the first and the last beyond it); then compound 1.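

In this assay the furan-2-yl hydrazone of compound 4 gives a 3.9-fold lower number from compound 1 to compound 4 (0.59 log units; beyond the scatter) against the free amino end, so the drop at this amide-type nitrogen is not confined to hydrazones carrying a substituted phenyl group. Furan-2-yl on the carbon with a double bond to nitrogen cannot be told apart from either phenyl group, since the reading of a 1.4-fold lower number from compound 3 to compound 4 (0.15 log units; within the scatter) and the reading of a 2.0-fold higher number from compound 2 to compound 4 (0.29 log units; within the scatter) both lie within the scatter, even though a 2.7-fold higher number from compound 2 to compound 3 (0.44 log units; beyond the scatter) lies beyond it; compound 4 therefore sits with both hydrazones and does not add a further rank to the series. No measurement on hand accounts for these numbers.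

Still open, going by these compounds, is whether a thiophene or pyridine ring in place of furan-2-yl stays in the same range, or whether a simple methyl group on that carbon already gives the same drop from compound 1. Also open, on these data alone, is how an amine or a carboxylic acid on the aromatic ring would read, since only hydroxy and chloro appear there.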